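A few compounds are considered here, and "the series" means these few. Any claim that something is new, unique, unknown or untested is made for them only; others in the source may bear on it.

Measured compounds:
Compound 2 `COc1ccc(Cl)cc1S(=O)(=O)Nc1cncc(C(N)=O)c1`: 105 nM
Compound 3 `COc1ccc(OC(F)(F)F)cc1S(=O)(=O)Nc1cncc(C(N)=O)c1`: 1560 nM
Compound 1 `COc1ccc(Cl)cc1S(=O)(=O)Nc1cncc(C(=O)Nc2ccccc2)c1`: "not determined" (no result reported)

For the measured compounds named here, in an assay on isolated protein for inhibition of alkaline phosphatase, tissue-nonspecific isozyme (Homo sapiens) (on this read-out higher numbers stand for weaker inhibition and lower numbers for stronger inhibition), compound 2 stands lowest of the two numbers; the one measured step, a 15-fold higher number from compound 2 to compound 3 (1.17 log units; beyond the scatter), is large. Compound 4 `CCNC(=O)c1cncc(NS(=O)(=O)c2cc(Cl)ccc2OC)c1` differs from compound 2 only by ethyl in place of hydrogen on an amide-type nitrogen. Going by the values given here, no measured step touches this nitrogen: the only step known changes a group on the aromatic ring, and compound 1, which carries a different group on the amide nitrogen, has no result. There is therefore nothing to scale an expectation by, and the expected step of a 1.7-fold higher number from compound 2 to compound 4 (0.23 log units; within the scatter) is modest. Compound 4 is estimated at 180 nM, within 50 nM to 700 nM.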

Compound 4, half-maximal inhibitory concentration: > 20000 nM
Compound 4: only a limit was reported; the forecaster's own chance of this, stated with the estimate: 5%; at least 110-fold (2.04 log units) between middle value and limit.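

For the compounds shown here, the amide nitrogen, which no earlier measured step had touched, proves highly sensitive to change. In this assay, adding just an ethyl group gives an at least 190-fold higher number from compound 2 to compound 4 (2.27 log units; beyond the scatter), so the amide hydrogen cannot be swapped for ethyl without a large loss of inhibition. The result for compound 4 is a limit of the assay and not a number: the limit of > 20000 nM in this assay, at which 1 of the 4 values shown sits.

As far as these compounds go, whether a methyl group on this nitrogen would be tolerated remains open, as does the effect of a longer chain. Compound 1, with a phenyl group on this nitrogen, has no result to help answer this.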